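Cinnamate to Benzoate: Dropping the Ethenyl Link

The source may hold more compounds than are shown below. What is called first, only, known or untested is meant among the compounds shown, and "the series" means these compounds.

Measured in an ADME assay on WI-38 cells (Homo sapiens) for inhibition, read by MTT assay, with a stated time of 72 h; a lower number here means a stronger inhibitor, a higher number a weaker inhibitor:
compound 1 `O=C(OC1(C(=O)Nc2ccc([N+](=O)[O-])cc2)CCCCC1)c1ccc([N+](=O)[O-])cc1` gives 761 nM
compound 2 `CCOC(=O)c1ccccc1C(=O)OC1(C(=O)Nc2ccc([N+](=O)[O-])cc2)CCCCC1` gives 386 nM
compound 3 `O=C(/C=C/c1ccccc1)OC1(C(=O)Nc2ccc([N+](=O)[O-])cc2)CCCCC1` gives 41 nM

Compound 3 has the lowest number of the three, with compound 2 nearest and compound 1 furthest. Compound 4 `O=C(OC1(C(=O)Nc2ccc([N+](=O)[O-])cc2)CCCCC1)c1ccccc1` differs from compound 3 by phenyl in place of 2-phenylethenyl on a carbonyl carbon. Among the measured compounds shown here, only one measured step touches this position: a 19-fold lower number from compound 1 to compound 3 (1.27 log units; beyond the scatter). That step exchanges 2-phenylethenyl for 4-nitrophenyl, not plain phenyl, so it does not show directly what removing the ethenyl link alone does. Still, compound 1, which carries a ring set straight on the carbonyl carbon, gives 761 nM, far above compound 3. A moderately higher number is therefore expected for compound 4, a 7.3-fold higher number from compound 3 to compound 4 (0.86 log units; beyond the scatter). Compound 4 is estimated at 300 nM, within 80 nM to 1100 nM.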

Compound 4, half-maximal inhibitory concentration: 246 nM
Compound 4: middle estimate off by 1.2-fold (0.09 log units), on the high side; measured number inside the range.
By their numbers in this assay, from the lowest: compound 3; then compounds 4, 2 and 1 (each within the scatter of the next, the first and the last beyond it).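

In this assay the ethenyl link counts on its own, with a 6.0-fold higher number from compound 3 to compound 4 (0.78 log units; beyond the scatter) and a phenyl ring kept in both. The nitro group also counts, with a 3.1-fold lower number from compound 1 to compound 4 (0.49 log units; beyond the scatter) as hydrogen replaces it, so the earlier step between these two substituents combined two separate changes. Ethoxycarbonyl gives no clear change, with a 1.6-fold lower number from compound 2 to compound 4 (0.20 log units; within the scatter) as hydrogen replaces it.

Nothing available explains why these steps differ in size. On these data alone, whether a longer chain in place of the ethenyl link, or an amine on the phenyl ring, would match compound 3 remains open.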